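The compounds below may be only part of what the source reports. "The series", "measured", "known", "first", "only" and "open" are said of these compounds alone.

Working notes on the series. All three measured compounds share the same core and differ only in the aryl group on the amine nitrogen. Compound 1 `O=C1C(Nc2ccccc2)=CC(=O)c2c1nc1n2[C@H]2OC[C@@H](O)[C@H]2OC1` carries a plain phenyl there and in a functional assay on ECa-109 cells for inhibition, with ECa-109 cell line (Homo sapiens) as the target, read by sulforhodamine B assay (on this read-out higher numbers stand for weaker inhibition and lower numbers for stronger inhibition), compound 1 gives 3560 nM, the second highest of the three numbers. Going by the values given here, compound 2 `CCOc1ccc(NC2=CC(=O)c3nc4n(c3C2=O)[C@H]2OC[C@@H](O)[C@H]2OC4)cc1` gives 3210 nM, and compound 3 `CCOc1ccccc1NC1=CC(=O)c2nc3n(c2C1=O)[C@H]1OC[C@@H](O)[C@H]1OC3` gives 4630 nM; the values of compound 1 and compound 2 lie within the scatter of each other, and the one measured step, a 1.4-fold higher number from compound 2 to compound 3 (0.16 log units; within the scatter), is likewise within the scatter.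

Compound 4 `CCOc1ccc(NC2=CC(=O)c3c(nc4n3[C@H]3OC[C@@H](O)[C@H]3OC4)C2=O)cc1` is not yet measured in this assay. Against compound 1 the change is ethoxy in place of hydrogen on an aromatic carbon. Among the compounds with values here, no measured step covers exactly this exchange, but compound 2 already carries the same 4-ethoxyphenyl and its value, 3210 nM, sits close to that of compound 1, while moving the ethoxy group gave a 1.4-fold higher number from compound 2 to compound 3 (0.16 log units; within the scatter). No step beyond the scatter is therefore expected: for compound 4 the estimate is a 1.0-fold lower number from compound 1 to compound 4 (0.02 log units; within the scatter), giving an expected value of 3400 nM with a range from 1700 nM to 7000 nM.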

Compound 4, half-maximal inhibitory concentration: > 4000 nM
Compound 4 gave a limit, no number; the forecaster's own chance of this, stated with the estimate: 5%; at least 1.1-fold (0.07 log units) between middle value and limit.
By their numbers in this assay, from the lowest: compounds 2, 1 and 3 (each within the scatter of the next).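

In this assay compound 4 gives > 4000 nM, which is a limit of the assay and not a number. The earlier compounds shown here offered no direct reading of the phenyl to 4-ethoxyphenyl exchange; here, ethoxy in place of hydrogen on an aromatic carbon, para to a large group, gives an at least 1.1-fold higher number from compound 1 to compound 4 (0.05 log units; that floor lies within the scatter), so this change shows no sign of stronger inhibition, while only a floor is known for its size. The reading for this exchange stops at a limit: the limit of > 4000 nM in this assay, at which 1 of the 4 values shown sits.

Open, as far as these compounds go, is how far the number of compound 4 lies past that floor, and so whether the true step goes beyond the scatter. Also open, from the compounds shown here alone, is how other groups on this aromatic carbon, such as methoxy, an amine or a carboxylic acid, would read against compound 1.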